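One Carbon Less in the Chain: A Second Test

This account rests on a few compounds, and the source may have more. Where it says the series, first, only, none or still open, it means among the compounds named here.

Measured so far:
compound 1, `CC(CC(=O)O)CC(=O)c1c(CCCCCCc2ccccc2)n(C)c2ccc(Cl)cc12`, 0.28 nM
compound 2, `CC(CC(=O)O)CC(=O)n1c(CCCCCc2ccccc2)cc2ccc(Cl)cc21`, 2.1 nM
compound 3, `CC(CC(=O)O)CC(=O)c1c(CCCCCc2ccccc2)n(C)c2ccc(Cl)cc12`, 11 nM

These three were tested in a functional assay for antagonist activity at Oxoeicosanoid receptor 1 (Homo sapiens), read by fluorescence and calcium flux, with stated times of 2 min and 1 min; a higher number here means a weaker inhibitor, a lower number a stronger inhibitor. Compound 1 gives 0.28 nM, and compound 3 gives 11 nM. The change between them is phenyl in place of benzyl on a saturated chain carbon, five bonds along the chain from an aromatic carbon; it made the step of a 39-fold higher number from compound 1 to compound 3 (1.59 log units; beyond the scatter). Compound 2 gives 2.1 nM; the difference between its core and the core of compound 1 is not broken down here.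

Compound 4, `CC(CC(=O)O)CC(=O)n1c(CCCCc2ccccc2)cc2ccc(Cl)cc21`, is not yet measured. It differs from compound 2 by phenyl in place of benzyl on a saturated chain carbon, four bonds along the chain from an aromatic carbon. Going by the values given here, this is the same kind of change as the one from compound 1 to compound 3, but not the same: there the place was five bonds along the chain from an aromatic carbon, here it is four bonds along the chain from an aromatic carbon, and the cores differ.

Because a 39-fold higher number from compound 1 to compound 3 (1.59 log units; beyond the scatter) points toward a weaker inhibitor when the chain loses one carbon, a weakening step is expected here as well, estimated as a 9.5-fold higher number from compound 2 to compound 4 (0.98 log units; beyond the scatter). This rests on a single precedent in a different core, so the estimate is uncertain. Compound 4 is expected to give about 20 nM, with a likely range from 4 nM to 100 nM.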

Compound 4, half-maximal inhibitory concentration: 18 nM
Compound 4: the middle estimate sits 1.1-fold (0.05 log units) above what was measured, within the range that was stated.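

In this assay, taking one carbon out of the chain again gave a weaker inhibitor, with an 8.6-fold higher number from compound 2 to compound 4 (0.93 log units; beyond the scatter), so the direction of this change held on the second core. Its size did not carry over, as the two steps differ by more than repeat measurements would explain: the same change on two cores in this assay, a 39-fold higher number (1.59 log units; beyond the scatter) from compound 1 to compound 3 and an 8.6-fold higher number (0.93 log units; beyond the scatter) from compound 2 to compound 4, 4.6-fold (0.66 log units) apart, beyond the scatter of two such steps

Going by these compounds alone, with only two pairs, this shows that the direction held in these compounds, not that it would hold on other cores, and it cannot separate the influence of the core from that of the place in the chain, which is five bonds along in one pair and four in the other.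

The compounds shown leave open whether a longer chain on the core of compound 2 would give a stronger inhibitor, or whether the strengthening stops at some chain length. They also leave open how an amine on the chain, or a fluoro group in place of the chloro group, would change the result.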